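A few compounds are considered here, and "the series" means these few. Any claim that something is new, unique, unknown or untested is made for them only; others in the source may bear on it.

Measured in a functional assay on the whole organism (stomach) for inhibition, with Rattus norvegicus as the target, at a dose of 100 mg/kg by the intraduodenal route; a lower number here means less inhibition, a higher number more inhibition at the dose given (going by the name of the read-out):
compound 1, `CC(CC(=N)S)n1ncccc1=O`: 38.8%
compound 2, `C/N=C(\S)CCn1ncccc1=O`: 35.7%

Compound 2 stands at the lower of the two numbers, yet its gap to compound 1 lies within the scatter, so the two cannot be set in order. Compound 3, `C/N=C(\S)CC(C)n1ncccc1=O`, is not yet measured; it differs from compound 2 by methyl in place of hydrogen on a saturated chain carbon bound to an aromatic nitrogen and a saturated chain carbon. Compound 1 already carries the same methyl on its chain and gives 38.8%, within the scatter of compound 2, so no change beyond the scatter is expected. The expected step in this assay is a number 1.3 percentage points higher from compound 2 to compound 3 (within the scatter). Compound 3 is therefore estimated at 37%, with a range from 25% to 50%.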

Compound 3, a percentage reported as inhibition, in the whole organism at one dose (the size of the read-out at that dose, not a potency): 42.7%
For compound 3 the middle estimate is 5.7 percentage points below the measured one; measured number inside the range.
By their numbers in this assay, from the lowest: compounds 2, 1 and 3 (each within the scatter of the next).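

In this assay, methyl in place of hydrogen on a saturated chain carbon bound to an aromatic nitrogen and a saturated chain carbon gives a number 7 percentage points higher from compound 2 to compound 3 (within the scatter), so this position carries the methyl with no change that stands clear of the scatter. With that methyl present, a group of 4 heavy atoms in place of a group of 3 heavy atoms at the chain end gives a number 3.9 percentage points higher from compound 1 to compound 3 (within the scatter), so neither change separates the compounds. No evidence on hand bears on these steps.

As far as these compounds go, whether an ethyl group or a longer chain at this carbon would move the number beyond the scatter stays open. So does the effect of an amine at this carbon.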